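Where the Fluorine Sits: From Compound 2 to Compound 3

The source may hold more compounds than are shown below. What is called first, only, known or untested is meant among the compounds shown, and "the series" means these compounds.

Two measured compounds share one core and differ only in the fluorophenyl group on the chain. Compound 1 `O=C(/C=C/c1cccc(F)c1)Nc1ccc(CC2=CC(=O)OC2)cc1` gives 13.1% in an assay on isolated protein for inhibition of DNA topoisomerase 1 (Homo sapiens), with a stated time of 30 min, tested at 100 uM; on this read-out lower numbers stand for less inhibition and higher numbers for more inhibition at the one concentration tested (going by the name of the read-out). Compound 2 `O=C(/C=C/c1ccccc1F)Nc1ccc(CC2=CC(=O)OC2)cc1` gives 11.7% in this assay. Among the measured compounds shown here, the single step between them, a number 1.4 percentage points lower from compound 1 to compound 2 (within the scatter), lies within the scatter, so the two cannot be told apart. Compound 2 thus holds the lower of the two numbers, but only by a margin the assay cannot resolve.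

Compound 3 `O=C(/C=C/c1ccc(F)cc1)Nc1ccc(CC2=CC(=O)OC2)cc1` has not yet been measured. It differs from compound 2 as 4-fluorophenyl in place of 2-fluorophenyl on a double-bonded chain carbon bound to a double-bonded chain carbon. For the measured compounds named here, the only measured step that bears on this change is the one from compound 1 to compound 2, which also moved the fluorine around the same ring and left the read-out essentially unchanged. A further move of that atom is therefore expected to give a step of a number 0.8 percentage points higher from compound 2 to compound 3 (within the scatter), none beyond the scatter. Compound 3 is expected to reach 12.5%, between 3% and 22%.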

Compound 3, a percentage reported as inhibition, at one concentration (the size of the read-out at that concentration, not a potency): 12.1%
For compound 3 the middle estimate is 0.4 percentage points above the measured one; low and high end bracket the measured number.
By their numbers in this assay, from the lowest: compounds 2, 3 and 1 (each within the scatter of the next).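

With this result, the 2-fluorophenyl, 3-fluorophenyl and 4-fluorophenyl groups have all been read on the shared core in this assay, and the fluorine's place on the ring makes no difference that this read-out can resolve. The new steps, a number 0.4 percentage points higher from compound 2 to compound 3 (within the scatter) and a number 1 percentage points lower from compound 1 to compound 3 (within the scatter), show that the 4-fluorophenyl compound cannot be told apart from either of the others, so all three form one flat set. No measurement shown here explains this flat result.

On these data alone, it remains open whether a different group at this place on the chain, such as a phenyl ring carrying a methoxy group, a chlorine or an amine, would move the number beyond the scatter. Since each compound was read at one concentration only, these numbers also give no potency for any of the three.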